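This account rests on a few compounds, and the source may have more. Where it says the series, first, only, none or still open, it means among the compounds named here.

Of the compounds shown here, three so far carry numbers in an ADME assay on L6 cells (Rattus norvegicus) for cytotoxicity; on this read-out lower numbers stand for stronger inhibition and higher numbers for weaker inhibition. Compound 1 (`O=C(CN1CCN(c2ccc(Cl)cc2)CC1)N1CCN(c2ccc(Cl)cc2)CC1`) gives 116000 nM, and compound 2 (`O=C(CN1CCN(c2ccc(C(F)(F)F)cc2)CC1)N1CCN(c2ccc(C(F)(F)F)cc2)CC1`) gives 31700 nM. Compound 3 (`N#Cc1ccccc1N1CCN(C(=O)Cn2cnc([N+](=O)[O-])n2)CC1`) gives 213000 nM. The number for compound 3 lies within the usual scatter of the number for compound 1, while compound 2 stands lower than compound 3 by more than the scatter.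

Compound 4 (`O=C(Cn1cnc([N+](=O)[O-])n1)N1CCN(c2ncccn2)CC1`) has not yet been measured. It has pyrimidin-2-yl in place of 2-cyanophenyl on an amine nitrogen in a ring. The rest of compound 3 is kept, including the shared core.

Going by the values given here, no two measured compounds differ in one place only, so the series offers no direct precedent for the size of this step. Nor do three values show which way the swap should push the number. The working expectation in this assay is therefore no step beyond the scatter, and the best anchor is compound 3 at 213000 nM. The expected change is a 1.1-fold higher number from compound 3 to compound 4 (0.05 log units; within the scatter). The estimate for compound 4 is 240000 nM, with an expected range of 100000 nM to 500000 nM.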

Compound 4, half-maximal inhibitory concentration: 150000 nM
The estimate for compound 4 lay 1.6-fold (0.20 log units) above the measured number, within the range that was stated.
By their numbers in this assay, from the lowest: compound 2; then compounds 1, 4 and 3 (each within the scatter of the next).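

Going by these compounds alone, the first single-place step reads, in this assay, a 1.4-fold lower number from compound 3 to compound 4 (0.15 log units; within the scatter), for pyrimidin-2-yl in place of 2-cyanophenyl on an amine nitrogen in a ring. This position therefore takes a six-membered aromatic ring with 2 hetero atoms in place of a carbon-only aromatic ring bearing a nitrile, without a step beyond the scatter, so on this one pair neither the nitrile nor the carbon-only ring is needed to keep the read-out where it stands. Nothing measured on these compounds speaks to why the step has this size.

A single step between two aromatic rings leaves open whether a group of another kind on that ring nitrogen, such as a simple alkyl chain or an aromatic ring carrying a carboxylic acid, would also stay within the scatter. Compounds 1 and 2 differ from compounds 3 and 4 in more than one place, so their numbers cannot be tied to this position, and the part of the structure that governs the read-out in this series remains unidentified.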